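A few compounds are considered here, and "the series" means these few. Any claim that something is new, unique, unknown or untested is made for them only; others in the source may bear on it.

For the measured compounds named here, compound 2 `CC(C)(C)OC(=O)N1CCC(OC(=O)c2cn(-c3ccc(C#N)cc3F)nn2)CC1` stands at the lower end of the two numbers measured so far: in an assay on HEK293 cells for agonist activity at Glucose-dependent insulinotropic receptor (Homo sapiens), read by a luciferase reporter, with a stated time of 24 h (on this read-out higher numbers stand for an effect only at larger amounts of compound and lower numbers for an effect already at smaller amounts), compound 2 gives 3.59 nM, while compound 1 `CC(C)(C)OC(=O)N1CCC(OC(=O)c2cn(-c3ccc(C(F)(F)F)cc3)nn2)CC1` gives 10.4 nM. Going by the values given here, the one step measured between them, a 2.9-fold lower number from compound 1 to compound 2 (0.46 log units; beyond the scatter), shows that exchanging the group on the aromatic nitrogen can move the read-out by a modest amount. Compound 3 `CC(C)(C)OC(=O)N1CCC(OC(=O)c2cn(-c3ccc(S(C)(=O)=O)cc3)nn2)CC1` has not yet been measured; it differs from compound 2 by 4-(methylsulfonyl)phenyl in place of 4-cyano-2-fluorophenyl on an aromatic nitrogen. Among the compounds with values here, only that single step bears on the question, and it involved a different pair of groups, so it says little about what a methylsulfonyl group will do here. The expectation is therefore a change of about a 1.7-fold higher number from compound 2 to compound 3 (0.22 log units; within the scatter), which may well fall within the scatter. For compound 3 the estimated value is 6 nM, with a range from 1.5 nM to 25 nM.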

Compound 3, half-maximal effective concentration: 3.67 nM
The estimate for compound 3 lay 1.6-fold (0.21 log units) above the measured number; low and high end bracket the measured number.
By their numbers in this assay, from the lowest: compounds 2 and 3 (each within the scatter of the next); then compound 1.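

In this assay, 4-(methylsulfonyl)phenyl on the aromatic nitrogen gives a 1.0-fold higher number from compound 2 to compound 3 (0.01 log units; within the scatter) and so cannot be told apart from 4-cyano-2-fluorophenyl, even though the two groups carry different atoms on the same six-membered aromatic ring. Methylsulfonyl in place of trifluoromethyl gives a 2.8-fold lower number from compound 1 to compound 3 (0.45 log units; beyond the scatter) and so compound 1 now stands apart, with two different groups at this position each giving a lower number beyond the scatter. Nothing available explains why compound 2 and compound 3 match in this assay.

The compounds shown leave open how a phenyl ring carrying an amine or a carboxylic acid would read at this position. The rest of the shared core is the same in all three compounds, so they say nothing about changes made there.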